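From cyclopropylmethyl to phenyl on a saturated ring carbon

A few compounds are considered here, and "the series" means these few. Any claim that something is new, unique, unknown or untested is made for them only; others in the source may bear on it.

In a functional assay on HOS cells (Homo sapiens) for antiproliferative activity, read by sulforhodamine B assay (a lower number here means a stronger inhibitor of growth, a higher number a weaker inhibitor of growth), compound 1 `CC[C@@H]1O[C@H](COCc2ccccc2)[C@@H](OCc2ccccc2)[C@H](OCc2ccccc2)[C@H]1O` gives 34200 nM. Compound 2 `O[C@@H]1[C@@H](OCc2ccccc2)[C@H](OCc2ccccc2)[C@@H](COCc2ccccc2)O[C@H]1CC1CC1` gives > 50000 nM, which is a limit of the assay and not a number. Compound 3 `O[C@@H]1[C@@H](OCc2ccccc2)[C@H](OCc2ccccc2)[C@@H](COCc2ccccc2)O[C@H]1c1ccccc1` carries phenyl in place of cyclopropylmethyl on a saturated ring carbon. For the measured compounds named here, only one measured step bears on this change, and it alters the same substituent: an at least 1.4-fold higher number from compound 1 to compound 2 (0.16 log units; that floor lies within the scatter). That single step sets no direction for phenyl, and the starting point is itself only a limit. No step beyond the scatter is therefore expected in this assay, and a further limit would be no surprise. The expected step is an at least 1.2-fold lower number from compound 2 to compound 3 (0.09 log units; that floor lies within the scatter). For compound 3 the estimated value is 40000 nM, with an expected range from 18000 nM to 90000 nM.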

Compound 3, concentration for 50% growth inhibition: > 50000 nM
Compound 3 was reported as a limit (the forecaster's own chance of this, stated with the estimate: 50%); middle value at least 1.2-fold (0.09 log units) from the limit.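

In this assay compound 3 gives > 50000 nM, which is a limit of the assay and not a number, and phenyl on this ring carbon therefore ends at the same limit as cyclopropylmethyl: the limit of > 50000 nM in this assay, at which 2 of the 3 values shown sit. The step between compound 2 and compound 3 cannot be read, as both values are limits. Phenyl in place of ethyl gives an at least 1.4-fold higher number from compound 1 to compound 3 (0.16 log units; that floor lies within the scatter), so neither replacement of the ethyl group of compound 1 shows any sign of stronger growth inhibition.

On these data alone, how far compound 2 and compound 3 actually lie beyond the limit stays unknown, and so does any order between them. Also open, as far as these compounds go, is whether an amine or a carboxylic acid on this same ring carbon would give a value that can be read and compared with compound 1.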